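The source may report more compounds than this note shows. Statements on the series, on what has been measured and on what is new or still open speak of the compounds shown alone.

Compound 1 `c1ccc2c(-c3cn4ccnc4c(-c4ccc5ncn(C6CCCCC6)c5c4)n3)cccc2c1` was tested in a functional assay on UACC-62 cells (Homo sapiens) for inhibition, read by sulforhodamine B assay, with a stated time of 48 h, tested at 10 uM (a lower number here means less inhibition, a higher number more inhibition at the concentration tested (going by the name of the read-out)), where compound 1 gives 16.7%. Its companion, compound 2 `Clc1ccc(-c2cn3ccnc3c(-c3ccc4ncn(C5CCCCC5)c4c3)n2)cc1`, differs from it in one place and in this assay compound 2 gives 30.5%. Going by the values given here, the single measured step, a number 13.8 percentage points higher from compound 1 to compound 2 (beyond the scatter), shows that trading the naphthalen-1-yl for a 4-chlorophenyl raises the read-out. On the numbers shown, compound 1 therefore stands lowest of the two, with compound 2 the only neighbour and beyond the scatter above it.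

Compound 3 `FC(F)(F)c1cccc(-c2cn3ccnc3c(-c3ccc4ncn(C5CCCCC5)c4c3)n2)c1` has not yet been measured. Its difference from compound 1 is 3-(trifluoromethyl)phenyl in place of naphthalen-1-yl on an aromatic carbon. Among the compounds with values here, the one step that bears on this is the step from compound 1 to compound 2. That step too removes the naphthalen-1-yl in favour of a group with one six-membered aromatic ring of carbon only, and it was modest and upward. A rise of roughly the same size is expected here, as a number 11.3 percentage points higher from compound 1 to compound 3 (beyond the scatter), though a single step gives only a rough guide. Compound 3 is therefore estimated to give 28% in this assay, with a range from 12% to 45%.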

Compound 3, a percentage reported as inhibition, at one concentration (the size of the read-out at that concentration, not a potency): 4.33%
Compound 3: the middle estimate sits 23.7 percentage points above what was measured; measured number below the stated range.
By their numbers in this assay, from the lowest: compound 3; then compound 1; then compound 2.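

The new result shows that losing the second ring of the naphthalen-1-yl does not by itself raise the read-out in this assay: the step to 3-(trifluoromethyl)phenyl runs the opposite way to the earlier change, as a number 12.4 percentage points lower from compound 1 to compound 3 (beyond the scatter) shows. Two groups with one six-membered aromatic ring of carbon only can also end up far apart at this position, with a number 26.2 percentage points lower from compound 2 to compound 3 (beyond the scatter) being the largest step among the three compounds, so the ring count alone does not set the outcome here, and what the ring carries matters. Nothing available explains why these groups behave so differently.

The compounds shown leave open whether the gap between compound 2 and compound 3 comes from the chlorine versus the trifluoromethyl or from where each sits on the ring, as these two compounds differ in both at once. Plain phenyl, 3-chlorophenyl and 4-(trifluoromethyl)phenyl would pull those two questions apart, and a phenyl carrying an amine or a carboxylic acid would show whether this position accepts a very different kind of group.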